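The compounds below may be only part of what the source reports. "The series", "measured", "known", "first", "only" and "open" are said of these compounds alone.

Measured compounds, read in a functional assay on MCF7 cells (Homo sapiens) for inhibition, read by sulforhodamine B assay; a higher number here means a weaker inhibitor, a lower number a stronger inhibitor:
compound 1 `CCCc1ccc(NC2=CC(=O)c3nc4n(c3C2=O)[C@H]2OC[C@@H](O)[C@H]2OC4)cc1`: 4660 nM
compound 2 `O=C1C=C(NCc2ccccc2)C(=O)c2c1nc1n2[C@H]2OC[C@@H](O)[C@H]2OC1`: > 8000 nM, a limit of the assay and not a number
compound 3 `O=C1C(NCc2ccccc2)=CC(=O)c2c1nc1n2[C@H]2OC[C@@H](O)[C@H]2OC1`: > 8000 nM, likewise a limit of the assay and not a number

Compound 4 `CCCc1ccc(NC2=CC(=O)c3c(nc4n3[C@H]3OC[C@@H](O)[C@H]3OC4)C2=O)cc1` is not yet measured. Compound 2 and compound 3 are built from the same atoms joined differently; the difference between the two cores is not broken down here. The change from compound 2 to compound 1 is 4-propylphenyl in place of benzyl on an amine nitrogen, and it gave an at least 1.7-fold lower number from compound 2 to compound 1 (0.23 log units; that floor lies within the scatter). The same change, (4-propylphenyl in place of benzyl on an amine nitrogen), carries compound 3 to compound 4, at the same place. The earlier step rests on (the limit of > 8000 nM in this assay, at which 2 of the 3 values shown sit), so only a floor is known for its size. For compound 4 the expected step is an at least 1.6-fold lower number from compound 3 to compound 4 (0.20 log units; that floor lies within the scatter), set beside the earlier one, because compound 1 reached 4660 nM in this assay with this very change on a core of the same atoms. Compound 4 is therefore estimated at 5000 nM, expected to fall between 2500 nM and 9000 nM, with a real chance that only a limit is again reported.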

Compound 4, half-maximal inhibitory concentration: > 4000 nM
Compound 4 gave a limit, no number; the forecaster's own chance of this, stated with the estimate: 35%; the middle value lies beyond the limit too.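

In this assay, compound 3 and compound 4 each carry only a limit of the assay and not a number, so no step can be read between them. Left open is whether 4-propylphenyl in place of benzyl on an amine nitrogen changes the number at all on the core of compound 3, and how any such change would compare with an at least 1.7-fold lower number from compound 2 to compound 1 (0.23 log units; that floor lies within the scatter).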